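Swapping Bromo for Methyl in Compound 2

This account rests on a few compounds, and the source may have more. Where it says the series, first, only, none or still open, it means among the compounds named here.

Compound 1 `Cc1ccc(C2=NN(C3=NC(c4ccccc4)CS3)C(c3cccc4ccccc34)C2)cc1`: 13300 nM
Compound 2 `O=C1CSC(N2N=C(c3ccc(Br)cc3)CC2c2cccc3ccccc23)=N1`: 14600 nM

Both compounds were tested in a functional assay on BGC-823 cells (Homo sapiens) for inhibition, read by CCK-8 assay, with a stated time of 48 h; a higher number here means a weaker inhibitor, a lower number a stronger inhibitor. Compound 2, at 14600 nM, cannot be told apart from compound 1, at 13300 nM, since the two values lie within the usual scatter of repeated measurements.

Compound 3 `Cc1ccc(C2=NN(C3=NC(=O)CS3)C(c3cccc4ccccc34)C2)cc1` has not yet been measured. It keeps the core of compound 2 and changes one place: methyl in place of bromo on an aromatic carbon. This puts methyl in place of bromo on an aromatic carbon, para to a large group, so that 4-bromophenyl becomes 4-methylphenyl.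

Among the measured compounds shown here, no pair of measured compounds shows this change on its own, so the data give no direct guide. Compound 1, at 13300 nM, does carry 4-methylphenyl, but it also differs elsewhere from compound 3, which makes it only a weak hint. In this assay no step beyond the scatter is expected, in either direction. The expected step of a 1.0-fold lower number from compound 2 to compound 3 (0.02 log units; within the scatter) is therefore small. For compound 3 the estimated value is 14000 nM, with an expected range of 6000 nM to 32000 nM.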

Compound 3, half-maximal inhibitory concentration: 10000 nM
Compound 3: the middle estimate sits 1.4-fold (0.15 log units) above what was measured; the measured number falls inside the stated range.
By their numbers in this assay, from the lowest: compounds 3, 1 and 2 (each within the scatter of the next).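

In this assay, methyl in place of bromo on the aromatic carbon gives a 1.5-fold lower number from compound 2 to compound 3 (0.16 log units; within the scatter). Among the compounds shown here, this is the first reading of that change on its own, and at this position the two groups cannot be told apart. The other change, on the amine nitrogen in a ring, keeps the 4-methylphenyl group and puts a group of 6 heavy atoms in place of a group of 11 heavy atoms, which gives a 1.3-fold lower number from compound 1 to compound 3 (0.12 log units; within the scatter), so the extra six-membered aromatic ring carried by compound 1 makes no readable difference in this assay either. Nothing available on these compounds explains why the numbers stay so close together.

The compounds shown carry only methyl and bromo at this position, so they leave open whether an amine, a carboxylic acid or a longer chain there would give a step beyond the scatter. For the compounds shown here, they also leave open whether any change to the shared core can separate one compound from another in these cells, as every step so far lies within the scatter.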